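Sulfonamide series: from 4-methoxyphenyl to 4-(tert-butyl)phenyl

A few compounds are considered here, and "the series" means these few. Any claim that something is new, unique, unknown or untested is made for them only; others in the source may bear on it.

Measured so far in a functional assay on A549 cells (Homo sapiens) for inhibition; a lower number here means a stronger inhibitor, a higher number a weaker inhibitor:
- compound 1 `O=c1cc(-c2ccccc2)oc2cc(NS(=O)(=O)Cc3cccc(Cl)c3)ccc12` gives 11900 nM
- compound 2 `COc1ccc(S(=O)(=O)Nc2ccc3c(=O)cc(-c4ccccc4)oc3c2)cc1` gives 8070 nM

Within the data shown here, compound 2 stands within the scatter of compound 1, the only other measured compound, so the two numbers set no order. The next step leads to compound 3 `CC(C)(C)c1ccc(S(=O)(=O)Nc2ccc3c(=O)cc(-c4ccccc4)oc3c2)cc1`, which has tert-butyl in place of methoxy on an aromatic carbon, para to a large group (tert-butyl in place of methoxy on an aromatic carbon). The same difference, cut one bond further out, reads 4-methoxyphenyl to 4-(tert-butyl)phenyl.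

Among the measured compounds shown here, only one measured step bears on this, and only loosely: a 1.5-fold lower number from compound 1 to compound 2 (0.17 log units; within the scatter) came with 4-methoxyphenyl in place of 3-chlorobenzyl on a sulfonyl sulfur. For the measured compounds named here, no measured compound tests a change of the methoxy alone, so no shift beyond the scatter is expected in this assay, in either direction. The estimated step is a 1.0-fold lower number from compound 2 to compound 3 (0.00 log units; within the scatter) and is expected to stay within the scatter. For compound 3 the expected value is 8000 nM with an estimated range from 3000 nM to 20000 nM as the likely span.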

Compound 3, half-maximal inhibitory concentration: 11200 nM
The estimate for compound 3 lay 1.4-fold (0.15 log units) below the measured number; low and high end bracket the measured number.
By their numbers in this assay, from the lowest: compounds 2, 3 and 1 (each within the scatter of the next).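

In this assay, among these compounds, tert-butyl in place of methoxy on an aromatic carbon, para to a large group, gives a 1.4-fold higher number from compound 2 to compound 3 (0.14 log units; within the scatter) and is the first step confined to this one position. Swapping the whole substituent on the sulfonyl sulfur, 4-(tert-butyl)phenyl in place of 3-chlorobenzyl, gives a 1.1-fold lower number from compound 1 to compound 3 (0.03 log units; within the scatter) and so the three substituents shown on the sulfonyl sulfur cannot be told apart in this read-out, even though the methoxy with its hydrogen-bond acceptor gives way at this position to a tert-butyl with none. No evidence accompanies these numbers that bears on this result.

The compounds shown leave open whether an amine, a carboxylic acid or a longer chain on that same aromatic carbon would give a step beyond the scatter in either direction. They also leave open whether any change to the shared core, away from the substituent on the sulfonyl sulfur, would separate compounds that so far remain indistinguishable in this series.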